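A few compounds are considered here, and "the series" means these few. Any claim that something is new, unique, unknown or untested is made for them only; others in the source may bear on it.

Measured so far in an assay on NIH3T3 cells with Urotensin-2 receptor (Homo sapiens) as the target; on this read-out lower numbers stand for an effect already at smaller amounts and higher numbers for an effect only at larger amounts of compound:
- compound 1, `Cc1cccc(C(=O)NC(CCN(C)C)c2ccc(Cl)cc2)c1C`: compound 1 gives 3630 nM
- compound 2, `Cc1ccccc1NC(=O)NC(CCN(C)C)c1ccc(Cl)cc1`: compound 2 gives 2290 nM

Compound 2 holds the lower of the two numbers in this assay; its nearest neighbour is compound 1, and the step of a 1.6-fold lower number from compound 1 to compound 2 (0.20 log units; within the scatter) lies within the scatter. Compound 3, `CN(C)CCC(NC(=O)NCc1ccccc1)c1ccc(Cl)cc1`, is the next compound in line. It differs from compound 2 by benzyl in place of 2-methylphenyl on an amide-type nitrogen. Going by the values given here, no measured step tests this kind of change: the only step available, a 1.6-fold lower number from compound 1 to compound 2 (0.20 log units; within the scatter), swaps one aryl group for another on the carbonyl side of the shared core and was itself within the scatter, so it gives no direction for moving from an aryl to a benzyl group on the same nitrogen. On that basis compound 3 is expected to stay close to compound 2, with a step of a 1.1-fold higher number from compound 2 to compound 3 (0.04 log units; within the scatter) that would not reach beyond the scatter. The estimate for compound 3 in this assay is therefore 2500 nM, within a range from 800 nM to 8000 nM.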

Compound 3, half-maximal effective concentration: 2000 nM
For compound 3 the middle estimate is 1.3-fold (0.10 log units) above the measured one, within the range that was stated.
By their numbers in this assay, from the lowest: compounds 3, 2 and 1 (each within the scatter of the next).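

In this assay the exchange of 2-methylphenyl for benzyl on an amide-type nitrogen gives a 1.1-fold lower number from compound 2 to compound 3 (0.06 log units; within the scatter) and thus shows that these two groups, each of 7 heavy atoms, cannot be told apart at this position. The wider change of 2,3-dimethylphenyl on a carbonyl carbon to benzylamino gives a 1.8-fold lower number from compound 1 to compound 3 (0.26 log units; within the scatter) and so also stays inside the scatter, which means that all three compounds remain indistinguishable in this read-out. No other information on these compounds is available to account for this result.

The compounds shown leave open whether a longer chain such as phenethyl, or a carboxylic acid, on this nitrogen would move the number beyond the scatter. They also leave open what replacing the dimethylamino group of the shared core with a primary amine would do.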